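The source may report more compounds than this note shows. Statements on the series, on what has been measured and on what is new or still open speak of the compounds shown alone.

In an ADME assay on microsomes from liver (Mus musculus, strain CD-1) for metabolic stability, read by LC-MS, tested at 2 uM (a lower number here means that the compound disappears faster, a higher number that the compound lasts longer), compound 1 `Cn1ccc2ccc(-c3cc(Nc4cnccc4C(=O)NCc4cncnc4)cc4nccnc34)cc21` gives 0.4 h, and compound 2 `CC(=O)N1CCCC(NC(=O)c2ccncc2Nc2cc(-c3ccc4ccn(C)c4c3)c3nccnc3c2)C1` gives 0.4 h. Compound 3 `CN1CC(NC(=O)c2ccncc2Nc2cc(-c3ccc4ccn(C)c4c3)c3nccnc3c2)C1` gives > 1 h, which is a limit and not a number. Compound 3 thus stands at the limit of > 1 h in this assay, at which 1 of the 3 values shown sits. Compound 4 `CN1CCC(N(C)C(=O)c2ccncc2Nc2cc(-c3ccc4ccn(C)c4c3)c3nccnc3c2)C1` carries methyl(1-methylpyrrolidin-3-yl)amino in place of (1-methylazetidin-3-yl)amino on a carbonyl carbon. Three measured steps changed the group on this same amide-type nitrogen: no change at the digits printed from compound 1 to compound 2 (within the scatter), an at least 2.5-fold higher number from compound 1 to compound 3 (0.39 log units; beyond the scatter) and an at least 2.5-fold higher number from compound 2 to compound 3 (0.39 log units; beyond the scatter). Both steps beyond the scatter brought in the 1-methylazetidin-3-yl group, which leaves here. A modest fall is therefore expected in this assay, estimated as an at least 1.6-fold lower number from compound 3 to compound 4 (0.22 log units; that floor lies within the scatter). Compound 4 is expected at 0.6 h, with an estimated range of 0.3 h to 1.2 h.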

Compound 4, half-life: > 1 h
Compound 4: a limit, no number; the forecaster's own chance of this, stated with the estimate: 25%; at least 1.6-fold (0.22 log units) between middle value and limit.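

In this assay, for the compounds shown here, the 1-methylazetidin-3-yl group is no longer the only group on this carbonyl carbon tied to the higher half-life: with methyl(1-methylpyrrolidin-3-yl)amino, the shared core shows an at least 2.5-fold higher number from compound 2 to compound 4 (0.39 log units; beyond the scatter) and an at least 2.5-fold higher number from compound 1 to compound 4 (0.39 log units; beyond the scatter). The amide hydrogen is also absent from compound 4, so it is not required for a half-life at this level. The step between compound 3 and compound 4 cannot be read, as each value is a limit: the limit of > 1 h in this assay, at which 2 of the 4 values shown sit.

Going by these compounds, how far compound 3 and compound 4 lie beyond that limit remains open. On these data alone, it is also open whether 1-methylpiperidin-3-yl on this amide nitrogen would keep the half-life at this level.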